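This account rests on a few compounds, and the source may have more. Where it says the series, first, only, none or still open, it means among the compounds named here.

In a functional assay on H157 cells (Homo sapiens) for antiproliferative activity, read by trypan blue exclusion (on this read-out higher numbers stand for weaker inhibition and lower numbers for stronger inhibition), compound 3 `COc1ccc(CS(=O)(=O)/C=C/c2ccc(F)cc2)cc1` gives 2500 nM, the lowest of the three numbers recorded. Compound 1 `COc1cc(OC)c(/C=C/S(=O)(=O)Cc2ccc(Cl)cc2)c(OC)c1` gives 15000 nM in this assay, and compound 2 `COc1cc(OC)c(/C=C/S(=O)(=O)Cc2ccc(O)cc2)c(OC)c1` gives 20000 nM. Compound 4 `COc1ccc(CS(=O)(=O)/C=C/c2ccc(N)cc2)cc1` differs from compound 3 by amino in place of fluoro on an aromatic carbon, on an aromatic carbon para to a large group. Within the data shown here, only one measured step bears on a swap of a small substituent at such a position: a 1.3-fold higher number from compound 1 to compound 2 (0.12 log units; within the scatter), which stayed within the scatter. Among the measured compounds shown here, on that evidence no step beyond the scatter is expected, although the single comparison is thin and concerns a different ring of the shared core. Compound 4 is therefore estimated at 3500 nM, with a range from 1000 nM to 12000 nM, which means an expected step of a 1.4-fold higher number from compound 3 to compound 4 (0.15 log units; within the scatter).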

Compound 4, half-maximal inhibitory concentration: > 20000 nM
Compound 4: only a limit was reported (the forecaster's own chance of this, stated with the estimate: 5%); middle value at least 5.7-fold (0.75 log units) away from the limit.
By their numbers in this assay, from the lowest: compound 3; then compounds 1 and 2 (each within the scatter of the next).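

In this assay, amino in place of fluoro on an aromatic carbon para to a large group is not a silent change: it gives an at least 8.0-fold higher number from compound 3 to compound 4 (0.90 log units; beyond the scatter). Among these compounds, the earlier swap of hydroxy for chloro, a 1.3-fold higher number from compound 1 to compound 2 (0.12 log units; within the scatter), stayed within the scatter, so this position is the first to show a step beyond it. The value of compound 4 is a limit and not a number: the limit of > 20000 nM in this assay, at which 1 of the 4 values shown sits.

Still open, from the compounds shown here alone, is how a nitrile, a methyl or a carboxylic acid would read at this position. Going by these compounds, how large the step truly is also stays open.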